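Swapping the phenol pattern on the hydrazone of compound 2

This account rests on a few compounds, and the source may have more. Where it says the series, first, only, none or still open, it means among the compounds named here.

Compound 2 `CN(C)CCn1cnnc1-c1cc(Oc2ccc(NC(=O)N/N=C/c3ccc(O)c(F)c3)cc2F)ccn1` is the weakest of the three measured compounds in a functional assay on A549 cells (Homo sapiens) for cytotoxicity, read by MTT assay, with a stated time of 72 h (a lower number here means a stronger inhibitor, a higher number a weaker inhibitor), giving 13400 nM. Compound 1 `CN(C)CCn1cnnc1-c1cc(Oc2ccc(NC(=O)N/N=C/c3ccc(Cl)cc3)cc2F)ccn1` gives 780 nM and compound 3 `CN(C)CCn1cnnc1-c1cc(Oc2ccc(NC(=O)N/N=C/c3cc(C(C)(C)C)cc(C(C)(C)C)c3O)cc2F)ccn1` gives 980 nM. Going by the values given here, the only single-point step among them is a 17-fold higher number from compound 1 to compound 2 (1.24 log units; beyond the scatter), showing that the aryl group at this position can move the number a great deal. Compound 4 `COc1ccc(/C=N/NC(=O)Nc2ccc(Oc3ccnc(-c4nncn4CCN(C)C)c3)c(F)c2)cc1O` differs from compound 2 by 3-hydroxy-4-methoxyphenyl in place of 3-fluoro-4-hydroxyphenyl on a carbon with a double bond to nitrogen. Among the compounds with values here, no measured step matches this exact change, so the expectation rests on the spread seen here: compound 2 is the outlier, and compound 3, which also carries a hydroxyl, sits far lower. For compound 4 a moderate improvement is therefore expected, a 2.7-fold lower number from compound 2 to compound 4 (0.43 log units; beyond the scatter), with an estimated value of 5000 nM and a range of 1500 nM to 16000 nM.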

Compound 4, half-maximal inhibitory concentration: > 100000 nM
Compound 4 ended at the assay's limit (the forecaster's own chance of this, stated with the estimate: 5%); middle value at least 20-fold (1.30 log units) away from the limit.
By their numbers in this assay, from the lowest: compounds 1 and 3 (each within the scatter of the next); then compound 2. At a limit, above all of these: compound 4.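

Compound 4 stands at a limit of this assay, not at a measured number: the limit of > 100000 nM in this assay, at which 1 of the 4 values shown sits. Replacing 3-fluoro-4-hydroxyphenyl with 3-hydroxy-4-methoxyphenyl gives an at least 7.4-fold higher number from compound 2 to compound 4 (0.87 log units; beyond the scatter), and replacing 4-chlorophenyl with the same group gives an at least 120-fold higher number from compound 1 to compound 4 (2.10 log units; beyond the scatter). A hydroxyl on this aryl group therefore does not settle the outcome, as compound 3 also carries one and gives 980 nM. Which part of the swap from compound 2 to compound 4 matters stays open, and so does how a phenyl ring carrying an amine or a carboxylic acid would behave here.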